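From phenyl to methyl on a saturated ring carbon

This account rests on a few compounds, and the source may have more. Where it says the series, first, only, none or still open, it means among the compounds named here.

Compound 1 `O=C(CCc1ccc(C(F)(F)F)cc1)Nc1ccc2nc(N3CCC(c4ccccc4)C3)ccc2c1`: 25 nM
Compound 2 `CCCN(CCC)c1ccc2cc(NC(=O)CCc3ccc(C(F)(F)F)cc3)ccc2n1`: 490 nM
Compound 3 `O=C(CCc1ccc(C(F)(F)F)cc1)Nc1ccc2nc(N3CCC3)ccc2c1`: 4 nM

In an assay on isolated protein for displacement of a labelled ligand from melanin-concentrating hormone receptor 1 (Homo sapiens) (on this read-out higher numbers stand for weaker inhibition and lower numbers for stronger inhibition), compound 1 stands second highest of the three numbers, with compound 3 nearest and compound 2 furthest. Compound 4 `CC1CCN(c2ccc3cc(NC(=O)CCc4ccc(C(F)(F)F)cc4)ccc3n2)C1` differs from compound 1 by methyl in place of phenyl on a saturated ring carbon. Going by the values given here, no measured step makes this exact change. Among the compounds with values here, the steps that bear on it are a 6.3-fold lower number from compound 1 to compound 3 (0.80 log units; beyond the scatter), where a smaller ring group on the aromatic carbon went with a lower number, and a 20-fold higher number from compound 1 to compound 2 (1.29 log units; beyond the scatter), where an acyclic group went with a far higher one. Compound 4 keeps the ring of compound 1 and only trims the group on it, so in line with the lowering in a 6.3-fold lower number from compound 1 to compound 3 (0.80 log units; beyond the scatter) a modest fall is expected in this assay, a 2.5-fold lower number from compound 1 to compound 4 (0.40 log units; beyond the scatter). Compound 4 is therefore estimated at 10 nM, within 3 nM to 30 nM.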

Compound 4, half-maximal inhibitory concentration: 2 nM
Beside the measured number, compound 4's estimate is 5.0-fold (0.70 log units) above it; measured number below the stated range.
By their numbers in this assay, from the lowest: compounds 4 and 3 (each within the scatter of the next); then compound 1; then compound 2.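

In this assay, methyl in place of phenyl on this saturated ring carbon gives a 13-fold lower number from compound 1 to compound 4 (1.10 log units; beyond the scatter), so the higher number of the phenyl compound does not go with the five-membered ring as such. Set against the azetidin-1-yl group, 3-methylpyrrolidin-1-yl gives a 2.0-fold lower number from compound 3 to compound 4 (0.30 log units; within the scatter), which lies within the scatter, and set against dipropylamino it gives a 250-fold lower number from compound 2 to compound 4 (2.39 log units; beyond the scatter). Nothing shown here offers a reason for these steps. The compounds shown leave open whether ethyl, hydroxyl or fluorine on this carbon, or plain pyrrolidin-1-yl with no group at all, would give a similar number.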